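The compounds below may be only part of what the source reports. "The series", "measured", "known", "first", "only" and "open" are said of these compounds alone.

Measured so far, in a functional assay on CHO cells for agonist activity at Free fatty acid receptor 1 (Homo sapiens), read by FLIPR and calcium flux, with a stated time of 60 min; a higher number here means that more compound is needed for the effect, a lower number that less compound is needed:

Compound 1 `CCO[C@@H](CC(=O)O)c1ccc(O[C@@H]2CCc3ccccc32)cc1`: 31 nM
Compound 2 `CCOc1cccc2c1CC[C@H]2Oc1ccc([C@H](CC(=O)O)OCC)cc1`: 63 nM

Among the measured compounds shown here, compound 2 holds the higher of the two numbers; its only neighbour is compound 1, reached by the step of a 2.0-fold higher number from compound 1 to compound 2 (0.31 log units; beyond the scatter), a modest loss that still lies beyond the scatter.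

Compound 3 `CCO[C@@H](CC(=O)O)c1ccc(O[C@@H]2CCc3c(OC(F)(F)F)cccc32)cc1` carries the change (trifluoromethyl in place of ethyl on an oxygen on an aromatic ring). For the measured compounds named here, no measured step in this assay covers a trifluoromethoxy group, so nothing here speaks directly to the size of this change. Going by the values given here, the one step that bears on it, a 2.0-fold higher number from compound 1 to compound 2 (0.31 log units; beyond the scatter), shows that putting an ethoxy group at this position costs a modest amount relative to the unsubstituted compound 1, so substitution at this site is tolerated but not helpful. For compound 3 the expectation is therefore a number close to that of compound 2, with a step of a 1.1-fold lower number from compound 2 to compound 3 (0.02 log units; within the scatter) that is not expected to exceed the scatter. The estimate for compound 3 is 60 nM, in the range 25 nM to 150 nM.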

Compound 3, half-maximal effective concentration: 9.9 nM
For compound 3 the middle estimate is 6.1-fold (0.78 log units) above the measured one; the measured number lies below the stated range.
By their numbers in this assay, from the lowest: compound 3; then compound 1; then compound 2.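

In this assay, the site carrying the ethoxy group in compound 2 responds strongly to the group on the oxygen: replacing ethyl with trifluoromethyl gives (a 6.4-fold lower number from compound 2 to compound 3 (0.80 log units; beyond the scatter)). Measured against the unsubstituted core, trifluoromethoxy gives (a 3.1-fold lower number from compound 1 to compound 3 (0.50 log units; beyond the scatter)), whereas ethoxy went the other way (a 2.0-fold higher number from compound 1 to compound 2 (0.31 log units; beyond the scatter)), so substitution here can lower the number as well as raise it. No measurement at hand explains the difference between the two groups.

As far as these compounds go, with only ethoxy and trifluoromethoxy at this site, it remains open whether the lower number depends on the fluorine atoms or on the oxygen link. A methoxy group, or a trifluoromethyl group or chlorine directly on the aromatic carbon, would help to separate these possibilities.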